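Isoxazole for methoxydimethylphenyl on a sulfonylacetic acid scaffold

A few compounds are considered here, and "the series" means these few. Any claim that something is new, unique, unknown or untested is made for them only; others in the source may bear on it.

Measured compounds:
compound 1, `COc1cc(C)c(-c2cccc(COc3ccc(S(=O)(=O)CC(=O)O)cc3)c2)c(C)c1`: 57.5 nM
compound 2, `Cc1cc(OCCCS(C)(=O)=O)cc(C)c1-c1cccc(COc2ccc(S(=O)(=O)CC(=O)O)cc2)c1`: 170 nM
compound 3, `CCC(C(=O)O)S(=O)(=O)c1ccc(OCc2cccc(-c3c(C)cc(OC)cc3C)c2)cc1`: > 1000 nM

In a functional assay on CHO cells for agonist activity at Free fatty acid receptor 1 (Homo sapiens), read by FLIPR and calcium flux (on this read-out higher numbers stand for an effect only at larger amounts of compound and lower numbers for an effect already at smaller amounts), compound 1 gives 57.5 nM, the lowest of the two numbers shown. Compound 2 differs by a 2-(methylsulfonyl)ethyl added to the methoxy carbon and gives a 3.0-fold higher number from compound 1 to compound 2 (0.47 log units; beyond the scatter). Compound 3 carries an ethyl on the chain carbon next to the acid, and in this assay compound 3 reaches only the limit (the limit of > 1000 nM in this assay, at which 1 of the 3 values shown sits).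

Compound 4, `Cc1noc(C)c1-c1cccc(COc2ccc(S(=O)(=O)CC(=O)O)cc2)c1`, changes the other end of the core: 3,5-dimethyl-1,2-oxazol-4-yl in place of 4-methoxy-2,6-dimethylphenyl on an aromatic carbon. Among the measured compounds shown here, neither measured step touches this aryl group, so they offer no direct guide; they show only that the shared core tolerates a modest change at the methoxy position but not at the acid chain. A smaller ring with a different acceptor pattern is expected to cost some potency, and the step from compound 1 is estimated at a 2.8-fold higher number from compound 1 to compound 4 (0.44 log units; beyond the scatter). For compound 4 the expected value in this assay is 160 nM, with a range from 50 nM to 600 nM.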

Compound 4, half-maximal effective concentration: 269 nM
Estimate against measurement, compound 4: 1.7-fold (0.23 log units) below; low and high end bracket the measured number.
By their numbers in this assay, from the lowest: compound 1; then compounds 2 and 4 (each within the scatter of the next). At a limit, above all of these: compound 3.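

Among the compounds shown here, this is the first measurement in which the aryl group on the shared core changes, and in this assay the change gives a 4.7-fold higher number from compound 1 to compound 4 (0.67 log units; beyond the scatter). The six-membered aromatic ring of carbon only can therefore give way to a five-membered aromatic ring with 2 hetero atoms, and compound 4 still gives a measured number, 269 nM, rather than a limit. The step is modest even though 3,5-dimethyl-1,2-oxazol-4-yl has fewer heavy atoms than 4-methoxy-2,6-dimethylphenyl and differs from it in its hetero atoms.

On these data alone, whether a pyridine ring, a pyrazole ring or an unsubstituted phenyl ring would fare the same at this place remains open, and this single pair cannot separate ring size from ring atoms. Nothing shown here accounts for the size of this step.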